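Working notes: chloro in place of hydrogen on compound 2

The source may report more compounds than this note shows. Statements on the series, on what has been measured and on what is new or still open speak of the compounds shown alone.

Measured so far, with values from a functional assay on Bel-7402 cells (Homo sapiens) for inhibition, read by MTT assay, with a stated time of 24 h, tested at 1 ug/mL (a higher number here means more inhibition of growth at the concentration tested, a lower number less inhibition of growth), as follows:
- compound 1 `CC(=O)SCCC(CCCCC(=O)Nc1ccc(Cl)cc1)SC(C)=O` gives 3.07%
- compound 2 `O=C(CCCCC(CCSC(=O)c1ccccc1)SC(=O)c1ccccc1)Nc1ccccc1` gives "not active" (no number reported)

Within the data shown here, compound 2 gives "not active" (no number reported) in this assay and so offers no single number to step from. Compound 3 `O=C(CCCCC(CCSC(=O)c1ccccc1)SC(=O)c1ccccc1)Nc1cccc(Cl)c1` differs from it in one place: chloro in place of hydrogen on an aromatic carbon and the phenyl becomes 3-chlorophenyl. Among the measured compounds shown here, no measured pair isolates this change. Compound 1 also carries a chloro on its aromatic ring, differs elsewhere, and gives 3.07% in this assay and this gives no ground to expect a step beyond the scatter. Compound 3 is expected at 3% (estimated range 0% to 12%).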

Compound 3, percent growth inhibition at one concentration: "not active" (no number reported)
The entry for compound 3 holds no number; the estimate stays without a comparison.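

In this assay compound 2 and compound 3 are both reported as "not active" without a number, so no step can be read between them. From the compounds shown here alone, whether chloro in place of hydrogen changes growth inhibition remains open. No other measurement bears on this result.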